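Compound 3 to compound 4: one group changes

This account rests on a few compounds, and the source may have more. Where it says the series, first, only, none or still open, it means among the compounds named here.

Measured so far in a physicochemical assay for solubility, in phosphate buffer, measured as kinetic solubility (a higher number here means a more soluble compound, a lower number a less soluble compound), for three compounds:
Compound 1 (`CC(C)C(/C=C1\NC(=O)NC1=O)c1ccc(-c2ccc3cccc(F)c3c2)[nH]c1=O`) gives 10700 nM
Compound 2 (`CC(C)C(c1ccc(-c2ccc3cccc(F)c3c2)[nH]c1=O)C1NC(=O)NC1=O`) gives 10600 nM
Compound 3 (`CC(C)C(c1ccc(-c2ccc3cccc(F)c3c2)[nH]c1=O)C1SC(=O)NC1=O`) gives 20100 nM

On these numbers, compound 3 cannot be told apart from the other two. The measured step of a 1.9-fold higher number from compound 1 to compound 3 (0.27 log units; within the scatter) and the measured step of a 1.9-fold higher number from compound 2 to compound 3 (0.28 log units; within the scatter) both stay within the scatter.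

Compound 4 (`CC(C)C(/C=C1\SC(=O)NC1=O)c1ccc(-c2ccc3cccc(F)c3c2)[nH]c1=O`) has not yet been measured. It keeps the core of compound 3 and changes one group: a group of 8 heavy atoms (4 carbon, 1 nitrogen, 2 oxygen, 1 sulfur; one five-membered non-aromatic ring with 2 hetero atoms) in place of a group of 7 heavy atoms (3 carbon, 1 nitrogen, 2 oxygen, 1 sulfur; one five-membered non-aromatic ring with 2 hetero atoms), on a saturated chain carbon bound to an aromatic carbon and a saturated chain carbon (the entering group has no common name).

Within the data shown here, the closest evidence comes from the one measured pair that differs by a similar change on a different ring. That pair gives a 1.0-fold lower number from compound 1 to compound 2 (0.00 log units; within the scatter) and runs in the opposite direction, from the larger group to the smaller. The swap to 2,4-dioxo-1,3-thiazolidin-5-yl in place of 2,5-dioxoimidazolidin-4-yl is also within the scatter, as the step from compound 2 shows. With a single such pair, the evidence is thin.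

No step beyond the scatter is therefore expected in this assay and the expected step is a 1.1-fold lower number from compound 3 to compound 4 (0.05 log units; within the scatter) for this change. For compound 4 an estimated 18000 nM is expected, within a range of 8000 nM to 40000 nM in the same read-out.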

Compound 4, solubility: 25600 nM
Estimate against measurement, compound 4: 1.4-fold (0.15 log units) below; the range from low to high includes it.
By their numbers in this assay, from the lowest: compounds 2, 1, 3 and 4 (each within the scatter of the next, the first and the last beyond it).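

Placing the entering group in this assay at the saturated chain carbon bound to an aromatic carbon and a saturated chain carbon, in place of 2,4-dioxo-1,3-thiazolidin-5-yl, gives a 1.3-fold higher number from compound 3 to compound 4 (0.11 log units; within the scatter), so this change leaves the read-out within the scatter on the sulfur-containing ring, as it does on the ring with two nitrogens in a 1.0-fold lower number from compound 1 to compound 2 (0.00 log units; within the scatter). Among these compounds, what the earlier compounds did not show is a step beyond the scatter at this position, and compound 4 now supplies two, a 2.4-fold higher number from compound 2 to compound 4 (0.38 log units; beyond the scatter) and a 2.4-fold higher number from compound 1 to compound 4 (0.38 log units; beyond the scatter), both of them modest. Compound 4 therefore stands apart from the two compounds with the ring with two nitrogens, yet it cannot be told apart from compound 3, so the separation rests on the top and bottom of a narrow series and not on any single change of the sulfur-containing pair.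

On these data alone, whether anything other than these two five-membered rings, such as a carboxylic acid or an amine on the same carbon, would move the read-out further remains open. Nothing shown here explains these steps.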